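This account rests on a few compounds, and the source may have more. Where it says the series, first, only, none or still open, it means among the compounds named here.

Measured so far in an ADME assay on HEK293 cells (Homo sapiens) for cytotoxicity, read by MTT assay, with a stated time of 48 h; a higher number here means a weaker inhibitor, a lower number a stronger inhibitor:
- compound 1, `O=C([C@H]1CCCN1S(=O)(=O)c1cc(Cl)ccc1Cl)N1CCN(c2ccnc3cc(Cl)ccc23)CC1`: 38000 nM
- compound 2, `O=C([C@H]1CCCN1S(=O)(=O)c1ccc2ccccc2c1)N1CCN(c2ccnc3cc(Cl)ccc23)CC1`: 24400 nM
- compound 3, `O=C([C@H]1CCCN1S(=O)(=O)c1ccccc1[N+](=O)[O-])N1CCN(c2ccnc3cc(Cl)ccc23)CC1`: 57700 nM

Compound 3 carries the highest of the three numbers, yet the separation is small: a 1.5-fold higher number from compound 1 to compound 3 (0.18 log units; within the scatter) stays within the scatter, while a 2.4-fold higher number from compound 2 to compound 3 (0.37 log units; beyond the scatter) is modest but beyond it. Compound 4, `Cc1ccc(S(=O)(=O)N2CCC[C@@H]2C(=O)N2CCN(c3ccnc4cc(Cl)ccc34)CC2)cc1`, differs from compound 3 in one place: 4-methylphenyl in place of 2-nitrophenyl on a sulfonyl sulfur. Both measured steps that bear on this position, a 1.5-fold higher number from compound 1 to compound 3 (0.18 log units; within the scatter) and a 2.4-fold higher number from compound 2 to compound 3 (0.37 log units; beyond the scatter), show that swapping the group on the sulfonyl sulfur has moved the number only a little. A further swap at the same place is therefore expected to stay in that narrow band, most likely giving a somewhat lower number than compound 3, close to compounds 1 and 2. Compound 4 is estimated at 35000 nM, within 15000 nM to 80000 nM, meaning an expected step of a 1.6-fold lower number from compound 3 to compound 4 (0.22 log units; within the scatter).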

Compound 4, half-maximal inhibitory concentration: 81200 nM
Estimate against measurement, compound 4: 2.3-fold (0.37 log units) below; the measured number lies above the stated range.
By their numbers in this assay, from the lowest: compounds 2, 1, 3 and 4 (each within the scatter of the next, the first and the last beyond it).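

In this assay, 4-methylphenyl and 2-nitrophenyl on the sulfonyl sulfur cannot be told apart, a 1.4-fold higher number from compound 3 to compound 4 (0.15 log units; within the scatter), yet 4-methylphenyl separates from the other two groups: a 2.1-fold higher number from compound 1 to compound 4 (0.33 log units; beyond the scatter) and a 3.3-fold higher number from compound 2 to compound 4 (0.52 log units; beyond the scatter). This position can therefore move the number beyond the scatter for more pairs than before, though each of these steps remains modest. Nothing measured here explains these differences. Still open, from the compounds shown here alone, is whether an amine, a carboxylic acid or a longer chain on the sulfonyl sulfur would stay in this narrow band.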